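The source may hold more compounds than are shown below. What is called first, only, known or untested is meant among the compounds shown, and "the series" means these compounds.

Of the compounds shown here, three from this series have been measured in a functional assay on OVCAR cells (Homo sapiens) for cytotoxicity, read by sulforhodamine B assay, with a stated time of 48 h; a lower number here means a stronger inhibitor, a higher number a weaker inhibitor. Compound 1 `CC(=O)N1N=C(c2ccccc2)CC1c1cccc(Cl)c1Cl` gives 36800 nM in this assay, the high end of the three numbers shown. Compound 2 `CC(=O)N1N=C(c2ccco2)CC1c1ccccc1[N+](=O)[O-]` gives 28300 nM in this assay, which lies within the scatter of compound 1. Compound 3 `CC(=O)N1N=C(c2ccco2)CC1c1ccc(N(C)C)cc1` gives 14600 nM in this assay, a gap from compound 1 that is beyond the scatter.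

Compound 4 `CC(=O)N1N=C(c2ccco2)CC1c1cccc(Cl)c1Cl` has not yet been measured. It differs from compound 1 in one place: furan-2-yl in place of phenyl on a carbon with a double bond to nitrogen. Among the compounds with values here, compounds 2 and 3 already carry this furan-2-yl on the shared core, and both sit at or below the number of compound 1, though no single-change step between measured compounds is available to fix the size of this exchange.

Compound 4 is therefore expected to give a number close to that of compound 1, with at most a modest lowering, so the step of a 1.4-fold lower number from compound 1 to compound 4 (0.15 log units; within the scatter) is estimated to stay within or near the scatter. The estimate for compound 4 in this assay is 26000 nM, with a range from 9000 nM to 70000 nM.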

Compound 4, half-maximal inhibitory concentration: 81200 nM
Compound 4: middle estimate off by 3.1-fold (0.49 log units), on the low side; measured number outside the range, above it.
By their numbers in this assay, from the lowest: compounds 3, 2 and 1 (each within the scatter of the next, the first and the last beyond it); then compound 4.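

In this assay, within the data shown here, furan-2-yl in place of phenyl on a carbon with a double bond to nitrogen gives a 2.2-fold higher number from compound 1 to compound 4 (0.34 log units; beyond the scatter), the first single-change reading at this position, and it points toward a weaker inhibitor, a modest step that lies beyond the scatter. Compound 4 gives 81200 nM, while compound 3, which carries the same furan-2-yl, gives 14600 nM, so this group on that carbon does not by itself bring a low number. Nothing available here accounts for the rise.

Going by these compounds, whether the exchange moves the number the same way alongside the other groups carried by compound 2 and compound 3 remains open. On these data alone, how a thiophen-2-yl or a pyridyl ring would read on this same carbon also remains open.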